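The compounds below may be only part of what the source reports. "The series", "measured", "known", "first", "only" and "open" are said of these compounds alone.

Compound 3 `O=C(Nc1ccc(Oc2ccc(-c3ncc[nH]3)cc2)cc1)Nc1ccc(F)c(C(F)(F)F)c1` stands highest of the three measured numbers in a functional assay on MDA-MB-231 cells (Homo sapiens) for inhibition, read by MTT assay and WST assay, with a stated time of 72 h, tested at 10 uM (on this read-out lower numbers stand for less inhibition of growth and higher numbers for more inhibition of growth at the one concentration tested), at 26.6%. Compound 1 `CC(=O)Oc1sccc1NC(=O)Nc1ccc(Oc2ccc(-c3nccs3)cc2)cc1` gives 11%, and compound 2 `O=C(Nc1ccc(Oc2ccc(-c3ncc[nH]3)cc2)cc1)Nc1ccc(Cl)c([N+](=O)[O-])c1` gives 3.36%. For the measured compounds named here, the one step among measured compounds, a number 23.2 percentage points higher from compound 2 to compound 3 (beyond the scatter), shows that the group on the amide-type nitrogen moves this read-out beyond the scatter. Compound 4 `CC(=O)Oc1sccc1NC(=O)Nc1ccc(Oc2ccc(-c3ncc[nH]3)cc2)cc1` differs from compound 3 by 2-acetoxythiophen-3-yl in place of 4-fluoro-3-(trifluoromethyl)phenyl on an amide-type nitrogen. Going by the values given here, no measured step covers this exchange directly; compound 1 carries the same 2-acetoxythiophen-3-yl group on a related core and sits well below compound 3. The step from compound 3 to compound 4 is therefore expected to be a loss, a number 14.6 percentage points lower from compound 3 to compound 4 (beyond the scatter). For compound 4 the estimate in this assay is 12%, with a range from 3% to 25%.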

Compound 4, percent growth inhibition at one concentration: -1.46%
Compound 4: middle estimate off by 13.5 percentage points, on the high side; measured number outside the range, below it.
By their numbers in this assay, from the lowest: compounds 4, 2 and 1 (each within the scatter of the next, the first and the last beyond it); then compound 3.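

In this assay, the 2-acetoxythiophen-3-yl group on the amide-type nitrogen gives a number 28.1 percentage points lower from compound 3 to compound 4 (beyond the scatter) and a number 4.8 percentage points lower from compound 2 to compound 4 (within the scatter), so among the groups at this place only 4-fluoro-3-(trifluoromethyl)phenyl stands apart. The group on the aromatic carbon also moves the number: with 2-acetoxythiophen-3-yl kept, 1H-imidazol-2-yl in place of 1,3-thiazol-2-yl gives a number 12.5 percentage points lower from compound 1 to compound 4 (beyond the scatter). Nothing measured here accounts for these shifts.

Open, going by these compounds, is whether a group carrying an amine or a carboxylic acid on the amide-type nitrogen would reach the number of compound 3. Also open, on these data alone, is whether 1,3-thiazol-2-yl in place of 1H-imidazol-2-yl would change the number in the same way when 4-fluoro-3-(trifluoromethyl)phenyl is present.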